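Flavanone triazole series: moving from compound 1 to compound 4

The compounds below may be only part of what the source reports. "The series", "measured", "known", "first", "only" and "open" are said of these compounds alone.

In a functional assay on RAW264.7 cells (Mus musculus) for inhibition, read by Griess assay, with stated times of 2 h and 24 h (on this read-out higher numbers stand for weaker inhibition and lower numbers for stronger inhibition), compound 1, with the structure `COc1ccc([C@@H]2CC(=O)c3c(O)cc(OCc4cn(Cc5ccc(C(F)(F)F)cc5)nn4)cc3O2)cc1O`, gives 17700 nM. This is the lowest of the three numbers recorded so far, but its distance to the other two compounds lies within the usual scatter. Compound 3, with the structure `COc1ccc([C@@H]2C/C(=N\O)c3c(O)cc(OCc4cn(Cc5ccccc5C)nn4)cc3O2)cc1O`, gives 18000 nM in this assay, and compound 2, with the structure `C#CCOc1cc(O)c2c(c1)O[C@H](c1ccc(OC)c(O)c1)C/C2=N\O`, gives 19100 nM in this assay. Within the data shown here, no single-point step between measured compounds is available, so the three measured values together describe a flat landscape in this assay.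

Compound 4, with the structure `COc1ccc([C@@H]2CC(=O)c3c(O)cc(OCc4cn(Cc5ccccc5Cl)nn4)cc3O2)cc1O`, has not yet been measured. It differs from compound 1 by a single change: 2-chlorophenyl in place of 4-(trifluoromethyl)phenyl on a saturated chain carbon bound to an aromatic nitrogen. Since no measured pair isolates such a change, there is no direct guide to its effect, and the closely grouped values of compound 1, compound 2 and compound 3 give no reason to expect a shift beyond the scatter in this assay.

The step of a 1.0-fold higher number from compound 1 to compound 4 (0.01 log units; within the scatter) is therefore expected to stay within the scatter. Compound 4 is estimated at 18000 nM in this assay, with a range from 9000 nM to 36000 nM.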

Compound 4, half-maximal inhibitory concentration: 6140 nM
For compound 4 the middle estimate is 2.9-fold (0.47 log units) above the measured one; the whole stated range lies above it.
By their numbers in this assay, from the lowest: compound 4; then compounds 1, 3 and 2 (each within the scatter of the next).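

In this assay, among these compounds, placing 2-chlorophenyl in place of 4-(trifluoromethyl)phenyl on a saturated chain carbon bound to an aromatic nitrogen gives a 2.9-fold lower number from compound 1 to compound 4 (0.46 log units; beyond the scatter), the first step in this set that isolates a single change. It shows that this position is not silent: the closely grouped earlier values could not reveal that a change here alone moves the number beyond the scatter, and this change moves it towards stronger inhibition. No further measurement bears on the origin of this step.

The change alters both the substituent and the name-given place on the aromatic ring, so this single pair cannot separate the loss of trifluoromethyl, the arrival of chlorine and the change of place from one another. It also leaves open how this position would respond to a plain benzyl group without any substituent, or to a benzyl group carrying an amine or a carboxylic acid, and whether the same change would have a similar effect on another part of the series.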